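A few compounds are considered here, and "the series" means these few. Any claim that something is new, unique, unknown or untested is made for them only; others in the source may bear on it.

Values so far in a physicochemical assay for solubility, read by spectrophotometry, in phosphate buffer, with a stated time of 18 h, at pH 7.4 (on this read-out higher numbers stand for higher solubility and lower numbers for lower solubility), are as follows.

- compound 1 `CCc1ccc(-c2nc3c(c(C)nn3-c3ccccc3)c(-c3ccccc3Cl)c2C#N)cc1` gives 1700 nM (chloro)
- compound 2 `CCc1ccc(-c2nc3c(c(C)nn3-c3ccccc3)c(-c3ccccc3F)c2C#N)cc1` gives 1700 nM (fluoro)
- compound 3 `CCc1ccc(-c2nc3c(c(C)nn3-c3ccccc3)c(-c3ccccc3C)c2C#N)cc1` gives 6000 nM (methyl)

Compound 3 stands highest of the three, and the gap to each of the other two lies beyond the scatter. The next analogue is compound 4 `CCc1ccc(-c2nc3c(c(C)nn3-c3ccccc3)c(-c3ccccc3C(F)(F)F)c2C#N)cc1` with the difference trifluoromethyl in place of methyl on an aromatic carbon in the same place, on an aromatic carbon ortho to a large group.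

Within the data shown here, two measured steps bear on this change, and both are modest: a 3.5-fold higher number from compound 1 to compound 3 (0.55 log units; beyond the scatter) and a 3.5-fold higher number from compound 2 to compound 3 (0.55 log units; beyond the scatter) with methyl entering in each case. The third step, no change at the digits printed from compound 1 to compound 2 (within the scatter) shows that these two replacements for methyl sit together. Among the measured compounds shown here, no trifluoromethyl compound has been measured, so the read-across is loose. Leaving methyl is expected to give a drop of similar size in this assay rather than no change. The expected move is a 3.0-fold lower number from compound 3 to compound 4 (0.48 log units; beyond the scatter) as an estimate. Compound 4 is estimated at 2000 nM with an expected range of 700 nM to 6000 nM on this read-out.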

Compound 4, solubility: 11000 nM
For compound 4 the middle estimate is 5.5-fold (0.74 log units) below the measured one, outside the stated range (above it).
By their numbers in this assay, from the lowest: compounds 1 and 2 (each within the scatter of the next); then compounds 3 and 4 (each within the scatter of the next).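

In this assay, trifluoromethyl on an aromatic carbon ortho to a large group reads alike with methyl (a 1.8-fold higher number from compound 3 to compound 4 (0.26 log units; within the scatter)), so the extra fluorines bring no separation between these two groups. Fluoro and chloro stay apart from it (a 6.5-fold higher number from compound 2 to compound 4 (0.81 log units; beyond the scatter); a 6.5-fold higher number from compound 1 to compound 4 (0.81 log units; beyond the scatter)), which divides the four compounds into two pairs: fluoro with chloro, methyl with trifluoromethyl. No measurement at hand accounts for this division.

Going by these compounds, whether the two pairs persist with other groups at this place, such as methoxy, an amine or a carboxylic acid, remains open. On these data alone, all four compounds also share the rest of the core of compound 1, so whether the division holds when the core is changed elsewhere is equally open.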